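The source may report more compounds than this note shows. Statements on the series, on what has been measured and on what is new or still open speak of the compounds shown alone.

Measured compounds:
compound 1 `COc1cc(-c2nnc3n2NC(c2cccs2)C(C(=O)c2ccc(F)cc2)S3)cc(OC)c1OC`: in a functional assay on HepG2 cells (Homo sapiens) for cytotoxicity, read by MTT assay, with a stated time of 48 h (a higher number here means a weaker inhibitor, a lower number a stronger inhibitor), compound 1 gives 54200 nM
compound 3 `COc1cc(-c2nnc3n2NC(c2cccs2)C(C(=O)c2ccc(Cl)cc2)S3)cc(OC)c1OC`: compound 3 gives 13200 nM
compound 2 `COc1cc(-c2nnc3n2NC(c2ccco2)C(C(=O)c2cccc(Br)c2)S3)cc(OC)c1OC`: compound 2 gives > 100000 nM, which is a limit of this assay rather than a number the limit of > 100000 nM in this assay, at which 1 of the 3 values shown sits.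

Compound 2 therefore stands apart from the two numbered values, with only a limit known. Compound 4 `COc1cccc(C(=O)C2Sc3nnc(-c4cc(OC)c(OC)c(OC)c4)n3NC2c2ccco2)c1` differs from compound 2 by methoxy in place of bromo on an aromatic carbon. Going by the values given here, the one measured step, a 4.1-fold lower number from compound 1 to compound 3 (0.61 log units; beyond the scatter), swaps one halogen for another on the carbonyl-bearing ring and shows that a small change there can shift the number modestly; it does not cover methoxy in place of bromo. Among the compounds with values here, no measured step matches the present change, so no direction beyond the scatter is expected, and a further limit is the likelier report. Compound 4 is expected to give 100000 nM, in the range 30000 nM to 300000 nM, an estimated a number no higher from compound 2 to compound 4 (the limit leaves the size open).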

Compound 4, half-maximal inhibitory concentration: > 100000 nM
Compound 4 ended at the assay's limit; the forecaster's own chance of this, stated with the estimate: 55%; the middle value lies on the limit itself.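

Compound 2 and compound 4 both give only a limit, not a number, so the step from bromo to methoxy cannot be read: the limit of > 100000 nM in this assay, at which 2 of the 4 values shown sit.

Still open, as far as these compounds go, is how far either compound lies past that limit, and whether methoxy or bromo gives the lower number.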